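Small N-alkyl variations on a shared adenine-like core

The compounds below may be only part of what the source reports. "The series", "measured", "known", "first", "only" and "open" are said of these compounds alone.

Measured so far, all in an assay on CHO cells for displacement of a labelled ligand from adenosine receptor A3 (Homo sapiens); on this read-out lower numbers stand for stronger inhibition and higher numbers for weaker inhibition:
compound 1 `CCn1cnc2ncnc(N)c21` gives > 100000 nM
compound 2 `CC(C)n1cnc2c(N)ncnc21` gives > 100000 nM
compound 3 `CCC(C)n1cnc2ncnc(N)c21` gives > 100000 nM

Each of these values is a limit of this assay, not a number. For compound 2 only the limit > 100000 nM is available, so its standing among the measured compounds cannot be read beyond that. Going by the values given here, the one step between measured compounds that differ in a single place, a step that the two limits leave unreadable from compound 1 to compound 3, is likewise unreadable, as the limit of > 100000 nM in this assay, at which 3 of the 3 values shown sit, makes plain.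

The next compound is compound 4 `CC(C)Cn1cnc2c(N)ncnc21`, which differs from compound 2 by isobutyl in place of isopropyl on an aromatic nitrogen. Among the compounds with values here, no measured step speaks to this change: the ethyl-for-hydrogen step from compound 1 to compound 3 sits between two limits and gives no size. Within the data shown here, with every value shown at the limit, a shift of the isopropyl to isobutyl on the aromatic nitrogen has no precedent in these data from which to expect a measurable gain.

Compound 4 is therefore expected at 100000 nM, with a range from 30000 nM to 300000 nM. The step this estimate implies, a number no higher from compound 2 to compound 4 (the limit leaves the size open), is expected to be none beyond the scatter, most likely again a limit.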

Compound 4, inhibition constant: > 100000 nM
Compound 4 ended at the assay's limit; the forecaster's own chance of this, stated with the estimate: 80%; the middle value sits exactly at the limit.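

Going by these compounds alone, compound 2 and compound 4 both sit at a limit, not a number, so no step between them can be read: the limit of > 100000 nM in this assay, at which 4 of the 4 values shown sit.

In this assay the compounds shown leave open whether any group on an aromatic nitrogen of the shared core gives a value that is not a limit.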